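The compounds below may be only part of what the source reports. "The series", "measured", "known", "first", "only" and "open" are said of these compounds alone.

Working notes on the series in a functional assay on MDA-MB-231 cells (Homo sapiens) for inhibition, read by sulforhodamine B assay, tested at 10 uM; on this read-out lower numbers stand for less inhibition and higher numbers for more inhibition at the one concentration tested (going by the name of the read-out).

Compound 1 `CN1CCN(c2ccc(C3=NNC(c4ccc(N(C)C)cc4)C3)cc2)CC1` is the unsubstituted parent of the shared core; in this assay compound 1 gives 11.4%. Compound 2 `CN1CCN(c2ccc(C3=NN(C(=O)CCCl)C(c4ccc(N(C)C)cc4)C3)cc2)CC1` carries a (2-chloroethyl)carbonyl on the ring amine nitrogen and in this assay compound 2 gives 2.4%. Compound 3 `CN1CCN(c2ccc(C3=NN(C(=O)c4ccc(F)cc4)C(c4ccc(N(C)C)cc4)C3)cc2)CC1` carries a (4-fluorophenyl)carbonyl at the same nitrogen and in this assay compound 3 gives 3.5%. The three measured steps are a number 9 percentage points lower from compound 1 to compound 2 (within the scatter), a number 7.9 percentage points lower from compound 1 to compound 3 (within the scatter) and a number 1.1 percentage points higher from compound 2 to compound 3 (within the scatter); none of them leaves the scatter, so the three compounds cannot be ranked against one another. Compound 3 stands second highest of the three numbers, closest to compound 2 and furthest from compound 1, both gaps within the scatter.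

Compound 4 `CN(C)c1ccc(C2CC(c3ccc(-n4cncn4)cc3)=NN2C(=O)c2ccc(F)cc2)cc1` differs from compound 3 only at the far end of the core: 1H-1,2,4-triazol-1-yl in place of 4-methylpiperazin-1-yl on an aromatic carbon. For the measured compounds named here, no measured step touches this position; the steps on record all concern the carbonyl group on the ring nitrogen and were all within the scatter, so no pointer for direction exists. For compound 4 the working expectation is therefore a number near that of compound 3, with a step of a number 1.5 percentage points higher from compound 3 to compound 4 (within the scatter) that is expected to stay within the scatter. The estimate for compound 4 is 5%, expected to fall between -5% and 16%.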

Compound 4, a percentage reported as inhibition, at one concentration (the size of the read-out at that concentration, not a potency): 12.5%
Compound 4: the middle estimate sits 7.5 percentage points below what was measured; measured number inside the range.
By their numbers in this assay, from the lowest: compounds 2, 3, 1 and 4 (each within the scatter of the next, the first and the last beyond it).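

In this assay, for the compounds shown here, the far end of the core is read for the first time: 1H-1,2,4-triazol-1-yl in place of 4-methylpiperazin-1-yl on an aromatic carbon, para to a large group, gives (a number 9 percentage points higher from compound 3 to compound 4 (within the scatter)). So at this position, with the (4-fluorophenyl)carbonyl held on the ring nitrogen, a five-membered aromatic ring can stand in place of a six-membered non-aromatic ring without a step beyond the scatter, and the single step gives no direction for the change. Nothing on hand offers an explanation for the size of this step.

Still open, from the compounds shown here alone, is whether the same exchange reads alike with the (2-chloroethyl)carbonyl or a hydrogen on the ring nitrogen, and what other groups at this position would give, such as morpholin-4-yl, a primary amine or a carboxylic acid. As every single-place step shown stays within the scatter, it also remains open whether any one change at either position can move the number beyond it.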